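Aryl variation on the acylhydrazone of compound 1

The source may hold more compounds than are shown below. What is called first, only, known or untested is meant among the compounds shown, and "the series" means these compounds.

Compound 1 `CN(C)CCn1cnnc1-c1cc(Oc2ccc(NC(=O)N/N=C/c3ccc(O)c(Br)c3)cc2F)ccn1` gives 450 nM in a functional assay on HT-29 cells (Homo sapiens) for cytotoxicity, read by MTT assay, with a stated time of 72 h (on this read-out lower numbers stand for stronger inhibition and higher numbers for weaker inhibition), the lowest of the three numbers measured. Compound 2 `CN(C)CCn1cnnc1-c1cc(Oc2ccc(NC(=O)N/N=C/c3ccccc3O[N+](=O)[O-])cc2F)ccn1` gives 950 nM and compound 3 `CN(C)CCn1cnnc1-c1cc(Oc2ccc(NC(=O)N/N=C/c3ccc(O)c(O)c3)cc2F)ccn1` gives 1890 nM. The step of a 2.1-fold higher number from compound 1 to compound 2 (0.32 log units; beyond the scatter) is modest, as is a 4.2-fold higher number from compound 1 to compound 3 (0.62 log units; beyond the scatter), while a 2.0-fold higher number from compound 2 to compound 3 (0.30 log units; within the scatter) is not a clear difference. Compound 4 `CN(C)CCn1cnnc1-c1cc(Oc2ccc(NC(=O)N/N=C/c3ccc(Cl)cc3)cc2F)ccn1` differs from compound 1 as follows: 4-chlorophenyl in place of 3-bromo-4-hydroxyphenyl on a carbon with a double bond to nitrogen Both measured changes to this aryl group gave higher numbers than compound 1, and the step to compound 3 shows that replacing bromo by hydroxy alone did so. Compound 4 is therefore expected to give a modestly higher number, estimated at 1000 nM with a range of 400 nM to 2500 nM. The expected step is a 2.2-fold higher number from compound 1 to compound 4 (0.35 log units; beyond the scatter).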

Compound 4, half-maximal inhibitory concentration: 530 nM
Beside the measured number, compound 4's estimate is 1.9-fold (0.28 log units) above it; the measured number falls inside the stated range.
By their numbers in this assay, from the lowest: compounds 1, 4, 2 and 3 (each within the scatter of the next, the first and the last beyond it).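

With 4-chlorophenyl on the carbon with a double bond to nitrogen, the hydroxy and bromo of compound 1 prove dispensable in this small set: the step is a 1.2-fold higher number from compound 1 to compound 4 (0.07 log units; within the scatter). The same group separates from 3,4-dihydroxyphenyl, with a 3.6-fold lower number from compound 3 to compound 4 (0.55 log units; beyond the scatter), but not from 2-(nitrooxy)phenyl, with a 1.8-fold lower number from compound 2 to compound 4 (0.25 log units; within the scatter). No measurement at hand accounts for these steps.

As far as these compounds go, whether the chlorine contributes at all remains open. An unsubstituted phenyl, or an aryl group carrying an amine or a carboxylic acid, would test how far this position tolerates change.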